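Methoxy to Ethoxy, Repeated on a Second Core

The compounds below may be only part of what the source reports. "The series", "measured", "known", "first", "only" and "open" are said of these compounds alone.

Measured in a functional assay on HCT-116 cells (Homo sapiens) for antiproliferative activity, with a stated time of 72 h; on this read-out higher numbers stand for weaker inhibition and lower numbers for stronger inhibition:
compound 1 `COc1ccccc1/C=C/c1nc2ccccc2c(=O)[nH]1` gives 2470 nM
compound 3 `CCOc1ccccc1/C=C/c1nc2ccccc2c(=O)[nH]1` gives 23300 nM
compound 2 `COc1ccc(/C=C/c2nc3ccccc3c(=O)[nH]2)cc1` gives only a limit, > 25000 nM

Compound 1 and compound 2 are built from the same atoms joined differently; the difference between the two cores is not broken down here. Compound 3 differs from compound 1 by methyl in place of hydrogen on a saturated chain carbon bound to an oxygen on an aromatic ring, and that change produced a 9.4-fold higher number from compound 1 to compound 3 (0.97 log units; beyond the scatter). For compound 2 the figure is a limit of this assay, (the limit of > 25000 nM in this assay, at which 1 of the 3 values shown sits).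

Compound 4 `CCOc1ccc(/C=C/c2nc3ccccc3c(=O)[nH]2)cc1` has not yet been measured; it differs from compound 2 by the same change, (methyl in place of hydrogen on a saturated chain carbon bound to an oxygen on an aromatic ring). Because a 9.4-fold higher number from compound 1 to compound 3 (0.97 log units; beyond the scatter), the step from compound 2 to compound 4 is expected to be a step that the limit leaves unreadable from compound 2 to compound 4, in the same direction. Compound 4 is therefore estimated at 60000 nM, within 25000 nM to 250000 nM, and most likely reported only as a limit again.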

Compound 4, half-maximal inhibitory concentration: > 25000 nM
Compound 4: only a limit was reported (the forecaster's own chance of this, stated with the estimate: 85%); the middle value is on the limit's open side.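

No step can be read from compound 2 to compound 4, since both are reported only as a limit in this assay: the limit of > 25000 nM in this assay, at which 2 of the 4 values shown sit.

The compounds shown leave open whether methoxy to ethoxy changes the number on the core of compound 2 as it did on the core of compound 1.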